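Aryl on the ring nitrogen: outlook for compound 4

The source may hold more compounds than are shown below. What is called first, only, known or untested is meant among the compounds shown, and "the series" means these compounds.

Measured so far in a functional assay on MCF7 cells (Homo sapiens) for inhibition, read by MTT assay, with a stated time of 72 h; a higher number here means a weaker inhibitor, a lower number a stronger inhibitor:
compound 1 `Cc1cc2occ(-c3nc(-c4ccccc4)c(-c4ccccc4)n3-c3ccccc3Cl)c(=O)c2cc1Cl`: 3120 nM
compound 2 `Cc1cc2occ(-c3nc(-c4ccccc4)c(-c4ccccc4)n3-c3ccc(Cl)c(Cl)c3)c(=O)c2cc1Cl`: 1560 nM
compound 3 `Cc1cc2occ(-c3nc(-c4ccccc4)c(-c4ccccc4)n3-c3cccc(Cl)c3)c(=O)c2cc1Cl`: 6250 nM

Compound 3 has the highest number of the three; its gap to compound 1 lies within the scatter, while a 4.0-fold higher number from compound 2 to compound 3 (0.60 log units; beyond the scatter). Compound 4 `Cc1ccc(-n2c(-c3coc4cc(C)c(Cl)cc4c3=O)nc(-c3ccccc3)c2-c2ccccc2)c(C)c1` is not yet measured. Change: 2,4-dimethylphenyl in place of 3-chlorophenyl on an aromatic nitrogen. The relevant steps are the aryl swaps on the ring nitrogen, a 2.0-fold lower number from compound 1 to compound 2 (0.30 log units; within the scatter) and a 2.0-fold higher number from compound 1 to compound 3 (0.30 log units; within the scatter), both within the scatter, and the modest 4.0-fold higher number from compound 2 to compound 3 (0.60 log units; beyond the scatter). For the measured compounds named here, no measured compound carries 2,4-dimethylphenyl, so the step is expected to be small, with a lean towards a lower number as for compound 1 with 3120 nM. Compound 4 is estimated at 3100 nM, range 1000 nM to 9500 nM, corresponding to an expected 2.0-fold lower number from compound 3 to compound 4 (0.30 log units; within the scatter).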

Compound 4, half-maximal inhibitory concentration: 6250 nM
For compound 4 the middle estimate is 2.0-fold (0.30 log units) below the measured one; the range from low to high includes it.
By their numbers in this assay, from the lowest: compounds 2, 1, 3 and 4 (each within the scatter of the next, the first and the last beyond it).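

In this assay, 2,4-dimethylphenyl on the aromatic nitrogen, an aryl without chlorine, reads the same as 3-chlorophenyl (no change at the digits printed from compound 3 to compound 4 (within the scatter)) and stays within the scatter of 2-chlorophenyl (a 2.0-fold higher number from compound 1 to compound 4 (0.30 log units; within the scatter)). For the compounds shown here, the one step beyond the scatter leads from 3,4-dichlorophenyl to the new group (a 4.0-fold higher number from compound 2 to compound 4 (0.60 log units; beyond the scatter)). No evidence on hand bears on these steps.

Still open, going by these compounds, is how an aryl bearing a methoxy group, an amine or a carboxylic acid would read at this nitrogen. On these data alone, a longer chain in place of the aryl is equally open.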